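The source may report more compounds than this note shows. Statements on the series, on what has been measured and on what is new or still open speak of the compounds shown alone.

Of the compounds shown here, three built on a shared core have been tested in a functional assay on MGC-803 cells (Homo sapiens) for inhibition, read by sulforhodamine B assay; a lower number here means a stronger inhibitor, a higher number a weaker inhibitor. Compound 1 `Cc1ccc(NC2=CC(=O)c3nc4n(c3C2=O)[C@H]2OC[C@@H](O)[C@H]2OC4)cc1C` carries a 3,4-dimethylphenyl on an amine nitrogen, and in this assay compound 1 gives 860 nM. Compound 3 `O=C1C=C(Nc2ccc(C(F)(F)F)cc2)C(=O)c2c1nc1n2[C@H]2OC[C@@H](O)[C@H]2OC1` carries a 4-(trifluoromethyl)phenyl there instead, and in this assay compound 3 gives 2820 nM. For the measured compounds named here, that single change is the only measured step: a 3.3-fold higher number from compound 1 to compound 3 (0.52 log units; beyond the scatter). Compound 2 `O=C1C(N2CCCCC2)=CC(=O)c2c1nc1n2[C@H]2OC[C@@H](O)[C@H]2OC1` carries piperidin-1-yl instead of an aniline. In this assay compound 2 gives > 4000 nM, which is a limit of the assay and not a number. Compound 2 therefore stands at the limit of > 4000 nM in this assay, at which 1 of the 3 values shown sits, and its distance from the other two cannot be stated.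

Compound 4 `CCCN(CCC)C1=CC(=O)c2c(nc3n2[C@H]2OC[C@@H](O)[C@H]2OC3)C1=O` differs from compound 2 in one place: dipropylamino in place of piperidin-1-yl on a double-bonded ring carbon. Going by the values given here, the measured step from compound 1 to compound 3 concerns aryl groups on the amine and does not bear on swapping one dialkylamino group for another, so no measured step speaks to this change. Compound 4 is expected to sit close to compound 2, and the step that the limit leaves unreadable from compound 2 to compound 4 is expected to be small. Compound 4 is estimated at 5000 nM, between 2500 nM and 12000 nM.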

Compound 4, half-maximal inhibitory concentration: > 16000 nM
Compound 4: only a limit was reported; the forecaster's own chance of this, stated with the estimate: 70%; middle value at least 3.2-fold (0.50 log units) away from the limit.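

Compound 2 and compound 4 are each reported only as a limit of the assay and not as a number, so the step between them cannot be read. The compounds shown leave open where either compound truly stands in this assay, and whether piperidin-1-yl or dipropylamino gives the lower number.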